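This account rests on a few compounds, and the source may have more. Where it says the series, first, only, none or still open, it means among the compounds named here.

Measured so far in this series:
compound 1, `Cc1ncnc2c1c(I)cn2[C@@H]1O[C@H](CO)[C@@H](O)[C@H]1O`: 12600 nM
compound 2, `COc1nc(N)nc2c1c(-c1ccccc1)cn2[C@@H]1O[C@H](CO)[C@@H](O)[C@H]1O`: > 20000 nM
compound 3, `Cc1nc(N)c2c(-c3ccco3)cn([C@@H]3O[C@H](CO)[C@@H](O)[C@H]3O)c2n1`: > 20000 nM

Within the data shown here, in a functional assay on CEM-DNR-bulk cells (Homo sapiens), read by MTT assay, with a stated time of 72 h (a higher number here means a weaker inhibitor, a lower number a stronger inhibitor), compound 1 gives 12600 nM, and it is the only compound of the three for which a number rather than a limit is recorded. For compound 2 the entry is a limit of the assay, > 20000 nM. For compound 3 the entry is likewise a limit of the assay, > 20000 nM. Among the measured compounds shown here, two of the three entries therefore sit at the limit of > 20000 nM in this assay, at which 2 of the 3 values shown sit, and compound 1 stands alone as the one compound with a measured half-maximal inhibitory concentration.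

The compound still to be measured is compound 4, `Cc1ncnc2c1c(-c1cccs1)cn2[C@@H]1O[C@H](CO)[C@@H](O)[C@H]1O`. It differs from compound 1 in one place: thiophen-2-yl in place of iodo on an aromatic carbon. For the measured compounds named here, no step between two measured compounds is available for this series, so the size of the change in this assay can only be expected, not read off. Going by the values given here, compounds 2 and 3 carry aromatic rings at the same sort of position and both reach only a limit, whereas the iodo compound 1 is the one with a number; the expectation is therefore a step toward weaker inhibition, though not clearly beyond the scatter. Compound 4 is estimated at 18000 nM, within 6000 nM to 55000 nM, which amounts to an expected step of a 1.4-fold higher number from compound 1 to compound 4 (0.15 log units; within the scatter).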

Compound 4, half-maximal inhibitory concentration: > 20000 nM
Compound 4 ended at the assay's limit; the forecaster's own chance of this, stated with the estimate: 45%; middle value at least 1.1-fold (0.04 log units) from the limit.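

In this assay, thiophen-2-yl in place of iodo on this aromatic carbon gives an at least 1.5-fold higher number from compound 1 to compound 4 (0.20 log units; that floor lies within the scatter), so the change has a floor but no measured size. Compound 4 gives > 20000 nM, which is a limit of the assay and not a number. This is the only pair shown that differs in one place, and it shows that on the core of compound 1, a five-membered aromatic ring at this carbon does not keep a measured half-maximal inhibitory concentration in reach of the assay, and the series now gathers at its ceiling: the limit of > 20000 nM in this assay, at which 3 of the 4 values shown sit.

On these data alone, how far the true step lies past its floor remains open, and with it whether the change from iodo to thiophen-2-yl exceeds the usual scatter at all. Also open, as far as these compounds go, is whether an amine or a carboxylic acid on this same aromatic carbon of the core of compound 1 would give a number in this assay, or would end at the same limit.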